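Dropping the chloro from compound 1: what to expect

The source may report more compounds than this note shows. Statements on the series, on what has been measured and on what is new or still open speak of the compounds shown alone.

Compound 1 `O=C(Nc1ccccc1O)C1CCc2ccccc2N1C(=O)c1ccccc1Cl` was tested in a functional assay on PC-3 cells (Homo sapiens) for cytotoxicity, read by sulforhodamine B assay, with a stated time of 72 h (a higher number here means a weaker inhibitor of growth, a lower number a stronger inhibitor of growth), and gave 60000 nM. Among the three measured compounds it holds the highest number. Compound 2 `COc1ccc(NC(=O)C2CCc3ccccc3N2)cc1` in this assay gives 56900 nM, a value that sits within the scatter of compound 1, so the two cannot be told apart. Compound 3 `CCC(=O)N1c2ccccc2CCC1C(=O)Nc1cc(C(F)(F)F)cc(C(F)(F)F)c1` in this assay gives 8540 nM, the lowest of the three and beyond the scatter from compound 1, so compound 3 is the stronger inhibitor of growth of that pair.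

Compound 4 `O=C(Nc1ccccc1O)C1CCc2ccccc2N1C(=O)c1ccccc1` has not been measured. It differs from compound 1 in one place: hydrogen in place of chloro on an aromatic carbon of a six-membered aromatic ring of carbon only, ortho to a large group; cut one bond further out, the change reads 2-chlorophenyl to phenyl. Within the data shown here, no pair of measured compounds shows this step, so there is no direct guide. Given how weak compound 1 already is at 60000 nM, the change is expected to stay within the scatter or at most to weaken the inhibitor a little. Compound 4 is therefore estimated at 70000 nM, with a range from 30000 nM to 160000 nM, and the expected step of a 1.2-fold higher number from compound 1 to compound 4 (0.07 log units; within the scatter) is small.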

Compound 4, concentration for 50% growth inhibition: 5690 nM
Compound 4: the middle estimate sits 12-fold (1.09 log units) above what was measured; measured number below the stated range.
By their numbers in this assay, from the lowest: compounds 4 and 3 (each within the scatter of the next); then compounds 2 and 1 (each within the scatter of the next).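

In this assay, the chloro of the 2-chlorophenyl group proves to be far from a silent detail: hydrogen in place of chloro on an aromatic carbon, ortho to a large group, gives an 11-fold lower number from compound 1 to compound 4 (1.02 log units; beyond the scatter), a large step beyond the scatter. The high number of compound 1 therefore does not belong to the shared core alone, as the same core with a plain benzoyl group in compound 4 gives 5690 nM, so a single chlorine atom on this ring decides much of the reading in this pair. Nothing at hand says what lies behind this step.

On these data alone, whether a fluoro group, a methyl group or an amine on that same aromatic carbon would read like chloro or like hydrogen stays open, and so does the question of whether only chloro at this place carries the penalty. As far as these compounds go, the step also rests on one pair, so it remains unknown whether it would recur with a different group at the other end of the molecule, and it cannot be taken as a rule for the wider series.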